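This account rests on a few compounds, and the source may have more. Where it says the series, first, only, none or still open, it means among the compounds named here.

Working notes on the series. In a functional assay on HCT-116 cells (Homo sapiens) for cytotoxicity, read by MTT assay, with a stated time of 72 h (a lower number here means a stronger inhibitor, a higher number a weaker inhibitor), compound 1 `COc1ccc(/C=C/C(=O)CC(C)=O)cc1OC` gives 4700 nM and compound 2 `COc1ccc(/C=C/C(=O)CC(C)=O)cc1` gives 11900 nM, the higher of the two numbers. Compound 3 `CC(=O)CC(=O)/C=C/c1ccc(O)cc1` is not yet measured. It differs from compound 2 by hydrogen in place of methyl on an oxygen on an aromatic ring, that is, methoxy to hydroxy. Among the compounds with values here, only one measured step bears on this, and only indirectly: a 2.5-fold higher number from compound 1 to compound 2 (0.40 log units; beyond the scatter), a modest step, came with hydrogen in place of methoxy on an aromatic carbon. Within the data shown here, there the whole methoxy leaves, whereas here only the methyl leaves, and no measured pair shows methoxy to hydroxy. Among the measured compounds shown here, with a 2.5-fold higher number from compound 1 to compound 2 (0.40 log units; beyond the scatter) as the sole guide, a step of similar modest size is expected in this assay, tentatively toward a lower number. The estimate amounts to an expected 2.2-fold lower number from compound 2 to compound 3 (0.34 log units; beyond the scatter). For compound 3 the estimated value is 5500 nM, with an expected range of 2000 nM to 15000 nM.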

Compound 3, half-maximal inhibitory concentration: 36500 nM
Beside the measured number, compound 3's estimate is 6.6-fold (0.82 log units) below it, outside the stated range (above it).
By their numbers in this assay, from the lowest: compound 1; then compound 2; then compound 3.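

In this assay, the methyl on the oxygen on the aromatic ring matters: its loss gives a 3.1-fold higher number from compound 2 to compound 3 (0.49 log units; beyond the scatter), so methoxy to hydroxy at this position is not a neutral change and does not recover activity. This step points the same way as a 2.5-fold higher number from compound 1 to compound 2 (0.40 log units; beyond the scatter), so both measured changes that remove a methoxy or its methyl move toward a higher number, and no compound shown goes against this. No available data bear on the reason for the step.

The compounds shown leave open whether a longer chain on this oxygen, such as ethoxy, would give a lower number than the methoxy of compound 2. They also leave open how an amine or a fluorine in place of this oxygen would compare with the methoxy and the hydroxy.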